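A few compounds are considered here, and "the series" means these few. Any claim that something is new, unique, unknown or untested is made for them only; others in the source may bear on it.

In a functional assay on CWR22R cells (Homo sapiens) for antiproliferative activity, read by CCK-8 assay, with a stated time of 6 days (on this read-out higher numbers stand for weaker inhibition and lower numbers for stronger inhibition), compound 1 (`C[C@@H](Cn1ccc(-c2ccc(C#N)c(Cl)c2)n1)NC(=O)c1ccccc1`) gives "not determined" (no result reported), so it offers no number to start from. Compound 3 (`C[C@@H](Cn1ccc(-c2ccc(C#N)c(Cl)c2)n1)NC(=O)c1ccccc1F`) likewise gives "not determined" (no result reported). Compound 2 (`C[C@@H](Cn1ccc(-c2ccc(C#N)c(Cl)c2)n1)NC(=O)c1cccc(OCC(O)CO)c1`) gives > 30000 nM, which is a limit of the assay and not a number. The only anchor for the series is thus (the limit of > 30000 nM in this assay, at which 1 of the 3 values shown sits). Next comes compound 4 (`C[C@@H](Cn1ccc(-c2ccc(C#N)c(Cl)c2)n1)Nc1cncnc1`). The change is pyrimidin-5-yl in place of benzoyl on an amine nitrogen. Its size cannot be read from compound 1, but in this assay compound 4 is expected to stay weak, with only a modest step toward stronger inhibition from the limit of compound 2. For compound 4 the estimated value is 10000 nM, with an expected range of 2000 nM to 30000 nM.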

Compound 4, half-maximal inhibitory concentration: > 30000 nM
Compound 4: only a limit was reported; the forecaster's own chance of this, stated with the estimate: 45%; middle value at least 3.0-fold (0.47 log units) from the limit.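

Compound 4 gives > 30000 nM, a limit and not a number, and compound 1 offers no number, so no step can be read between them. From the compounds shown here alone, whether pyrimidin-5-yl in place of benzoyl changes inhibition at all stays open.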